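The compounds below may be only part of what the source reports. "The series", "measured", "known", "first", "only" and "open" are said of these compounds alone.

Measured compounds:
- Compound 1 `Cn1cnc(CN2CCN(c3cccc4[nH]c(-c5ccc(C(C)(C)C)cc5)nc34)CC2)c1`; in an assay on isolated protein for displacement of a labelled ligand from Gonadotropin-releasing hormone receptor (Rattus norvegicus) (a lower number here means a stronger inhibitor, a higher number a weaker inhibitor), compound 1 gives 98 nM.
- Compound 2 `Cc1nc(CN2CCN(c3cccc4[nH]c(-c5ccc(C(C)(C)C)cc5)nc34)CC2)c[nH]1`; in this assay compound 2 gives 28 nM.
- Compound 3 `CCc1nc(C)c(CN2CCN(c3cccc4[nH]c(-c5ccc(C(C)(C)C)cc5)nc34)CC2)s1`; in this assay compound 3 gives 120 nM.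

Compound 2 holds the lowest number of the three, the others lying beyond the scatter: a 3.5-fold lower number from compound 1 to compound 2 (0.54 log units; beyond the scatter) and a 4.3-fold higher number from compound 2 to compound 3 (0.63 log units; beyond the scatter), while a 1.2-fold higher number from compound 1 to compound 3 (0.09 log units; within the scatter).

Compound 4 `CCc1cc(CN2CCN(c3cccc4[nH]c(-c5ccc(C(C)(C)C)cc5)nc34)CC2)nn1C` is not yet measured. (5-ethyl-1-methyl-1H-pyrazol-3-yl in place of 2-methyl-1H-imidazol-4-yl on a saturated chain carbon bound to an amine nitrogen in a ring). The entering group, like those of compound 1 and compound 3, carries no hydrogen-bond donor, and the two steps that bear on this, a 3.5-fold lower number from compound 1 to compound 2 (0.54 log units; beyond the scatter) and a 4.3-fold higher number from compound 2 to compound 3 (0.63 log units; beyond the scatter), both place the donor-bearing compound 2 modestly lower. A modest rise is therefore expected here, a 3.4-fold higher number from compound 2 to compound 4 (0.53 log units; beyond the scatter).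

Compound 4 is estimated at 95 nM, range 40 nM to 250 nM.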

Compound 4, half-maximal inhibitory concentration: 350 nM
Estimate against measurement, compound 4: 3.7-fold (0.57 log units) below, and the stated range ends below it.
By their numbers in this assay, from the lowest: compound 2; then compounds 1 and 3 (each within the scatter of the next); then compound 4.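

Groups without a hydrogen-bond donor do not share one level at this position in this assay: 5-ethyl-1-methyl-1H-pyrazol-3-yl gives the largest step seen here (a 13-fold higher number from compound 2 to compound 4 (1.10 log units; beyond the scatter)) and also stands apart from the other two such groups (a 3.6-fold higher number from compound 1 to compound 4 (0.55 log units; beyond the scatter); a 2.9-fold higher number from compound 3 to compound 4 (0.46 log units; beyond the scatter)). Lacking the donor therefore does not by itself set the number for this change. No measurement at hand bears on what lies behind the rise.

Going by these compounds, whether the ethyl or the methyl of the pyrazole goes with the rise stays open. Also open, on these data alone, is where a 1H-pyrazol-3-yl carrying neither group, or a 2-pyridyl, would fall relative to compound 2.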